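The source may hold more compounds than are shown below. What is called first, only, known or untested is meant among the compounds shown, and "the series" means these compounds.

Compound 1 `C#Cc1cccc(NC(=O)CCc2cccc3c2B(O)OC3)c1` carries an ethynyl group on the aromatic ring attached to the amide. In a functional assay on MDA-MB-231 cells (Homo sapiens) for antiproliferative activity, read by MTT assay, with a stated time of 72 h (on this read-out lower numbers stand for stronger inhibition and higher numbers for weaker inhibition), compound 1 gives 1600 nM, the lower of the two numbers in hand. Compound 2 `O=C(CCc1cccc2c1B(O)OC2)Nc1ccccc1-c1ccccc1`, a related analogue, gives 18000 nM in this assay, a higher number beyond the usual scatter, which on this read-out means weaker inhibition. Compound 3 `N#Cc1ccc(-c2cccc(NC(=O)CCc3cccc4c3B(O)OC4)c2)cc1` has not yet been measured; its change from compound 1 is 4-cyanophenyl in place of ethynyl on an aromatic carbon. Going by the values given here, no measured step of this kind exists, so only a small shift, at most a modest loss, is expected, as a 1.9-fold higher number from compound 1 to compound 3 (0.27 log units; within the scatter). Compound 3 is estimated at 3000 nM, within a range from 800 nM to 12000 nM.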

Compound 3, half-maximal inhibitory concentration: 380 nM
Beside the measured number, compound 3's estimate is 7.9-fold (0.90 log units) above it; the measured number lies below the stated range.
By their numbers in this assay, from the lowest: compound 3; then compound 1; then compound 2.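

At this aromatic carbon, 4-cyanophenyl can stand in place of ethynyl with no loss: in this assay the change gives a 4.2-fold lower number from compound 1 to compound 3 (0.62 log units; beyond the scatter) and so counts as a modest gain. This shows that the position takes a much larger group, with a whole extra aromatic ring, which compound 1 alone could not show. Nothing at hand explains why the number falls. Still open, going by these compounds, is whether the nitrile itself matters, or whether the added ring would serve equally well bearing an amine or a carboxylic acid instead.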